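Removing the methyl from the aryl ketone of compound 3

This account rests on a few compounds, and the source may have more. Where it says the series, first, only, none or still open, it means among the compounds named here.

Compound 1 `COc1cc(-c2nnc3n2NC(c2ccco2)C(C(=O)c2ccccc2C)S3)cc(OC)c1OC`: 80000 nM in a functional assay on A549 cells (Homo sapiens) for cytotoxicity, read by MTT assay, with a stated time of 48 h; on this read-out higher numbers stand for weaker inhibition and lower numbers for stronger inhibition
Compound 2 `COc1cc(-c2nnc3n2NC(c2ccco2)C(C(=O)c2ccc(Br)cc2)S3)cc(OC)c1OC`: 42100 nM
Compound 3 `COc1cc(-c2nnc3n2NC(c2cccs2)C(C(=O)c2ccc(C)cc2)S3)cc(OC)c1OC`: 12700 nM

Compound 3 gives the lowest number of the three; compound 2 is nearest and compound 1 furthest, and both of those gaps lie beyond the scatter. Compound 4 `COc1cc(-c2nnc3n2NC(c2cccs2)C(C(=O)c2ccccc2)S3)cc(OC)c1OC` differs from compound 3 by hydrogen in place of methyl on an aromatic carbon. For the measured compounds named here, the only measured step on that aryl ketone is a 1.9-fold lower number from compound 1 to compound 2 (0.28 log units; within the scatter), which stayed within the scatter although it swapped a different substituent. Going by the values given here, no step removes a methyl, so the expectation rests on that single small step: a change a 1.4-fold higher number from compound 3 to compound 4 (0.15 log units; within the scatter) that is expected to be modest, leaning toward a slightly higher number. Compound 4 is therefore estimated at 18000 nM, ranging from 8000 nM to 45000 nM.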

Compound 4, half-maximal inhibitory concentration: 69400 nM
Estimate against measurement, compound 4: 3.9-fold (0.59 log units) below, and the stated range ends below it.
By their numbers in this assay, from the lowest: compound 3; then compounds 2, 4 and 1 (each within the scatter of the next).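

In this assay, for the compounds shown here, taking the methyl off the 4-methylphenyl ketone gives a 5.5-fold higher number from compound 3 to compound 4 (0.74 log units; beyond the scatter) and so shows that this single carbon, para to a large group, matters far more than the one earlier step on the aryl ketone suggested. Even a change of one heavy atom at this place moves the number beyond the scatter. Nothing available explains this difference.

Going by these compounds, whether an ethyl, a methoxy or an amine at this place would hold the number of compound 3 stays open. Also open, on these data alone, is whether the methyl counts as much when the rest of the compound differs.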